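Methyl for trifluoromethyl on a methoxy-bearing amide series

This account rests on a few compounds, and the source may have more. Where it says the series, first, only, none or still open, it means among the compounds named here.

Compound 2, `COc1ccc2sc(NC(=O)c3ccc(C(F)(F)F)cc3)nc2c1`, is the starting point of this step. In a functional assay on MDA-MB-231 cells (Homo sapiens) for antiproliferative activity, read by sulforhodamine B assay (a lower number here means a stronger inhibitor of growth, a higher number a weaker inhibitor of growth), compound 2 gives only a limit of the assay, > 10 ug/mL, and no number. (the limit of > 10 ug/mL in this assay, at which 2 of the 3 values shown sit), so compound 2 shares its position with one other member, while the third value shown is a number. Compound 1, `Cc1cc(C)c2sc(NC(=O)c3ccc(C(F)(F)F)cc3)nc2c1`, gives 0.45 ug/mL in this assay. Compound 3, `COc1cccc2sc(NC(=O)c3ccc(C#N)cc3)nc12`, gives in this assay a limit and no number, > 10 ug/mL. Compound 1 and compound 3 each differ from compound 2 in more than one place, and their values say only what each of them shows on its own.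

Compound 4, `COc1ccc2sc(NC(=O)c3ccc(C)cc3)nc2c1`, has not yet been measured in this assay. It differs from compound 2 in a single place: methyl in place of trifluoromethyl on an aromatic carbon. No measured pair differs only in this way, so the size of such a step is not known from the numbers shown.

Because compound 2 gives > 10 ug/mL, a limit, compound 4 is expected to stay close to that limit. The step that the limit leaves unreadable from compound 2 to compound 4 is expected to be none beyond the scatter. The estimate for compound 4 in this assay is 15 ug/mL, within 5 ug/mL to 40 ug/mL.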

Compound 4, concentration for 50% growth inhibition: > 10 ug/mL
Compound 4: no number, only a limit; the forecaster's own chance of this, stated with the estimate: 70%; the middle value is on the limit's open side.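

Compound 2 and compound 4 both stand at a limit of this assay, not at a number, and no step between them can be read: the limit of > 10 ug/mL in this assay, at which 3 of the 4 values shown sit.

Left open is the size of any effect of methyl in place of trifluoromethyl on an aromatic carbon in this assay, in a pair where both compounds give numbers.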